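This account rests on a few compounds, and the source may have more. Where it says the series, first, only, none or still open, it means among the compounds named here.

The measured compounds:
compound 1, `COc1ccc2c(O[C@@H]3C[C@H]4C(=O)N[C@]5(C(=O)NS(=O)(=O)C6CC6)C[C@H]5/C=C\CCCCCNC(=O)N4C3)cc(-c3nc(C(C)C)cs3)nc2c1`, 10 10^-6 cm/s
compound 2, `COc1ccc2c(O[C@@H]3C[C@H]4C(=O)N[C@]5(C(=O)NS(=O)(=O)C6(C)CC6)C[C@H]5/C=C\CCCCCNC(=O)N4C3)cc(-c3nc(C(C)C)cs3)nc2c1`, 30 10^-6 cm/s
compound 3, `COc1ccc2c(O[C@@H]3C[C@H]4C(=O)N[C@]5(C(=O)NS(=O)(=O)C6CC6)C[C@H]5/C=C\CCCCCNC(=O)N4C3)cc(-c3nccs3)nc2c1`, 0.4 10^-6 cm/s

In an ADME assay on Caco-2 cells (Homo sapiens) for permeability, in the apical to basolateral direction (a higher number here means that the compound crosses the layer faster, a lower number that the compound crosses the layer more slowly), compound 1 stands second highest of the three measured values; compound 2 lies above it and compound 3 far below. Compound 4, `COc1ccc2c(O[C@@H]3C[C@H]4C(=O)N[C@]5(C(=O)NS(=O)(=O)C6CC6)C[C@H]5/C=C\CCCCCNC(=O)N4C3)cc(-c3nc(C(C)C)cs3)nc2c1C`, differs from compound 1 by methyl in place of hydrogen on an aromatic carbon: a methyl enters on an aromatic carbon of the six-membered carbon ring of the fused system, ortho to the methoxy group. For the measured compounds named here, two measured steps bear on this change. The step of a 3.0-fold higher number from compound 1 to compound 2 (0.48 log units; beyond the scatter) places a methyl on a saturated ring carbon and gives a modest rise. The step of a 25-fold lower number from compound 1 to compound 3 (1.40 log units; beyond the scatter) removes an isopropyl from an aromatic carbon and gives a large fall. In both, the compound carrying the extra carbon gave the higher number, though neither step touches the ring where the new methyl sits. A modest rise in this assay is therefore expected for compound 4, a 1.7-fold higher number from compound 1 to compound 4 (0.23 log units; within the scatter), while a result within the scatter would not surprise. Compound 4 is estimated at 17 10^-6 cm/s, with a range from 7 10^-6 cm/s to 40 10^-6 cm/s.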

Compound 4, apparent permeability: 0.4 10^-6 cm/s
For compound 4 the middle estimate is 43-fold (1.63 log units) above the measured one; the whole stated range lies above it.
By their numbers in this assay, from the lowest: compounds 3 and 4 (each within the scatter of the next); then compound 1; then compound 2.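

In this assay, the step of a 25-fold lower number from compound 1 to compound 4 (1.40 log units; beyond the scatter) shows that a single methyl on this aromatic carbon, ortho to a methoxy group, goes with a large fall. The earlier compounds shown here gave no sign of this: the methyl on a saturated ring carbon in the step of a 3.0-fold higher number from compound 1 to compound 2 (0.48 log units; beyond the scatter) moved the number the opposite way, so the direction of the change from an added methyl differs between these two places on compound 1. No measurement at hand accounts for the fall.

On these data alone, whether a fluorine, a chlorine or a hydroxyl on this same aromatic carbon would go with a similar fall remains open. As far as these compounds go, it is also open whether the methyl here would have the same outcome when combined with the methylated saturated ring of compound 2.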